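Amide replacement on the sulfonyl-piperazine core: cytotoxicity notes

This account rests on a few compounds, and the source may have more. Where it says the series, first, only, none or still open, it means among the compounds named here.

Measured compounds and values:
- compound 1, `CC(C(=O)N1CC2CC2C1)N1CCN(S(=O)(=O)c2ccc(C(C)(C)C)cc2)CC1`, > 40000 nM
- compound 2, `CC(C(=O)N1CCC(F)(F)CC1)N1CCN(S(=O)(=O)c2ccc(C(C)(C)C)cc2)CC1`, > 40000 nM
- compound 3, `CC(C(=O)N1CCC2(CC1)CC2)N1CCN(S(=O)(=O)c2ccc(C(C)(C)C)cc2)CC1`, > 40000 nM

In an ADME assay on HepG2 cells (Homo sapiens) for inhibition, with a stated time of 48 h (on this read-out higher numbers stand for an effect only at larger amounts of compound and lower numbers for an effect already at smaller amounts), compound 1 reaches only a limit of the assay, > 40000 nM. In this assay compound 2 likewise sits at a limit, > 40000 nM. In this assay compound 3 also returns a limit, > 40000 nM. None of the three gives a number, so compound 1 cannot be placed relative to the others; all three share the same position, (the limit of > 40000 nM in this assay, at which 3 of the 3 values shown sit).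

Compound 4, `CC(C(=O)N1CCN(C)CC1)N1CCN(S(=O)(=O)c2ccc(C(C)(C)C)cc2)CC1`, has not yet been measured in this assay. It differs from compound 1 at the amide: a group of 7 heavy atoms (5 carbon, 2 nitrogen; one six-membered non-aromatic ring with 2 hetero atoms) in place of a group of 6 heavy atoms (5 carbon, 1 nitrogen; one three-membered non-aromatic ring of carbon only, one five-membered non-aromatic ring with 1 hetero atom), on a carbonyl carbon.

Among the compounds with values here, the steps that bear on this change are a step that the two limits leave unreadable from compound 1 to compound 2 and a step that the two limits leave unreadable from compound 1 to compound 3; both exchange the same group on the carbonyl carbon for another ring and both are unreadable, since each end sits at the limit. The same holds for a step that the two limits leave unreadable from compound 2 to compound 3. Within the data shown here, nothing among the measured compounds therefore points to a readable effect of varying this amide in this assay, and no step beyond the scatter is expected.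

Compound 4 is expected to return a limit as well, estimated at 60000 nM with a range of 30000 nM to 150000 nM, which would mean a step that the limit leaves unreadable from compound 1 to compound 4, a step expected to be unreadable for the same reason.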

Compound 4, half-maximal effective concentration: > 40000 nM
Compound 4: no number, only a limit; the forecaster's own chance of this, stated with the estimate: 85%; the middle value lies beyond the limit too.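

In this assay compound 4 returns only a limit, > 40000 nM. No step from compound 1, compound 2 or compound 3 to compound 4 can be read, and all four compounds share one position: the limit of > 40000 nM in this assay, at which 4 of the 4 values shown sit.

The compounds shown leave open whether any amide on the shared core gives a numerical value in this assay.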